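Removing the chloro from the aryl ring of compound 3

A few compounds are considered here, and "the series" means these few. Any claim that something is new, unique, unknown or untested is made for them only; others in the source may bear on it.

Compound 3 `O=C1C2=C(C(=O)c3ncccc31)C1(CS2)NC(=O)N(c2ccc(Cl)cc2)C1=O` gives 10 nM in a functional assay on MT4 cells (Homo sapiens) for antiproliferative activity, read by MTT assay, with a stated time of 96 h; a higher number here means a weaker inhibitor, a lower number a stronger inhibitor. Of the single numbers shown it has the lowest, but its nearest neighbour, compound 1 `CN(C)c1ccc(N2C(=O)NC3(CSC4=C3C(=O)c3ncccc3C4=O)C2=O)cc1`, gives 15 nM in this assay, and the two lie within the scatter of each other. Compound 2 `O=C1NC(=O)C2(CSC3=C2C(=O)c2ncccc2C3=O)N1`, which carries no aryl group on the nitrogen of the shared core, gives 130 nM; 120 nM; 130 nM (3 entries) in this assay over repeated measurements (the several entries of compound 2 in this assay, 130 nM; 120 nM; 130 nM (3 entries)).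

The change to compound 4 `O=C1C2=C(C(=O)c3ncccc31)C1(CS2)NC(=O)N(c2ccccc2)C1=O` is hydrogen in place of chloro on an aromatic carbon. Going by the values given here, only one measured step speaks to a substituent on that aryl ring: a 1.5-fold lower number from compound 1 to compound 3 (0.18 log units; within the scatter). There, one substituent was exchanged for another and the number barely moved, so the aryl ring appears tolerant of what it carries, at least across the two groups tried. Nothing measured shows the bare ring itself; compound 2 and compound 3 merely show what the absence of the whole aryl group looks like beside its presence.

The step from compound 3 to compound 4 is therefore expected to be small, about a 1.5-fold higher number from compound 3 to compound 4 (0.18 log units; within the scatter), not beyond the scatter in either direction. Compound 4 is expected to give 15 nM, estimated to fall between 6 nM and 40 nM.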

Compound 4, half-maximal inhibitory concentration: 25 nM
Beside the measured number, compound 4's estimate is 1.7-fold (0.22 log units) below it; measured number inside the range.
By their numbers in this assay, from the lowest: compounds 3, 1 and 4 (each within the scatter of the next, the first and the last beyond it).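

The bare ring is what this result adds at this position, on an aromatic carbon para to a large group: going from 4-chlorophenyl to phenyl gives a 2.5-fold higher number from compound 3 to compound 4 (0.40 log units; beyond the scatter) in this assay, so the loss of the chloro can be read, though only modestly, while a 1.7-fold higher number from compound 1 to compound 4 (0.22 log units; within the scatter) shows no separation from the dimethylamino compound. An unsubstituted phenyl also keeps most of what the aryl group brings, since compound 4, at 25 nM, still has a lower number than compound 2, at 130 nM; 120 nM; 130 nM (3 entries). The close agreement of the repeated measurements available here lends some weight to reading a step this modest: the several entries of compound 2 in this assay, 130 nM; 120 nM; 130 nM (3 entries).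

From the compounds shown here alone, with only chloro, dimethylamino and hydrogen on this carbon, the three numbers form a short, overlapping series that ties the change to no feature of the groups, and it remains open whether a fluoro, a methoxy or a carboxylic acid would sit with compound 3 or with compound 4. Going by these compounds, it also remains open whether chloro on any other aromatic carbon of this ring would give a similar step.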